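The source may report more compounds than this note shows. Statements on the series, on what has been measured and on what is new or still open speak of the compounds shown alone.

Measured compounds:
compound 1, `COC(=O)CC1c2ccccc2N=C(NCCCCCN)N1c1ccc(-c2ccccc2)cc1`: 560 nM
compound 2, `CCN1C(N2CCCCC2)=Nc2ccccc2C1CC(=O)NCc1ccc(NS(=O)(=O)c2ccc(C)cc2)cc1`: 960 nM

Both were tested in a functional assay on SK-MEL-2 cells (Homo sapiens) for inhibition, read by sulforhodamine B assay; on this read-out lower numbers stand for stronger inhibition and higher numbers for weaker inhibition. Compound 2 gives 960 nM and so holds the highest of the two numbers; its nearest neighbour is compound 1 with 560 nM, and the gap between the two lies within the usual scatter of repeated measurements, so nothing can be said about which of them inhibits more strongly. Among the measured compounds shown here, no pair among the measured compounds differs in just a single place, so no measured step is available to lean on.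

Compound 3, `Cc1ccc(S(=O)(=O)Nc2ccc(CNC(=O)CC3c4ccccc4N=C(N4CCCCC4)N3c3ccccc3)cc2)cc1`, is the next compound to be measured in this assay. It departs from compound 2 in one place: phenyl in place of ethyl on an amine nitrogen in a ring. For the measured compounds named here, with no measured pair showing the effect of such a change, the expectation rests on the two numbers alone. The step of a 1.4-fold lower number from compound 2 to compound 3 (0.14 log units; within the scatter) is expected to be small, leaning toward a slightly lower number, and quite possibly nothing beyond the scatter. The estimate for compound 3 in this assay is 700 nM, within a range of 250 nM to 2000 nM.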

Compound 3, half-maximal inhibitory concentration: 170 nM
Compound 3: the middle estimate sits 4.1-fold (0.61 log units) above what was measured; the whole stated range lies above it.
By their numbers in this assay, from the lowest: compound 3; then compounds 1 and 2 (each within the scatter of the next).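

Phenyl in place of ethyl on the amine nitrogen in the ring gives the first step in this assay that lies beyond the scatter, a 5.6-fold lower number from compound 2 to compound 3 (0.75 log units; beyond the scatter). This shows that the group on this nitrogen, next to the ring atom that bears the piperidin-1-yl group, can shift the number, and that a six-membered aromatic ring of carbon only, with 6 heavy atoms in place of 2, is accepted there with stronger inhibition rather than a loss of it. Nothing available gives a reason for this step.

It remains open whether the aromatic ring itself matters or the added carbons alone would do, a question that a cyclohexyl group or a longer alkyl chain on this nitrogen would help to settle, and neither stands among the compounds shown. Also open, on these data alone, is whether a phenyl carrying a further group, such as methoxy or fluorine, would move the number further in either direction, and whether the same change would give a step of similar size with a different group in place of the piperidin-1-yl group.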